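A few compounds are considered here, and "the series" means these few. Any claim that something is new, unique, unknown or untested is made for them only; others in the source may bear on it.

Measured so far: compound 1 `COc1cccc(OC)c1OCCNCCOc1ccccc1OCc1ccccc1` gives 0.537 nM in an assay on CHO cells for displacement of a labelled ligand from Alpha-1B adrenergic receptor (Homo sapiens); a higher number here means a weaker inhibitor, a lower number a stronger inhibitor; compound 2 `COc1cccc(OC)c1OCCNCCOc1ccccc1OCc1ccccc1Cl` gives 0.562 nM in this assay.

Compound 2 stands highest of the two numbers, though its step from compound 1, a 1.0-fold higher number from compound 1 to compound 2 (0.02 log units; within the scatter), lies within the scatter. Compound 3 `COc1ccc(COc2ccccc2OCCNCCOc2c(OC)cccc2OC)cc1` differs from compound 2 by 4-methoxyphenyl in place of 2-chlorophenyl on a saturated chain carbon bound to an oxygen on an aromatic ring. Going by the values given here, the only measured step touching this part of the molecule, a 1.0-fold higher number from compound 1 to compound 2 (0.02 log units; within the scatter), was small, so no move beyond the scatter is expected. The estimate for compound 3 is 0.65 nM, within 0.22 nM to 2.2 nM, a step of a 1.2-fold higher number from compound 2 to compound 3 (0.06 log units; within the scatter) expected from compound 2.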

Compound 3, inhibition constant: 0.398 nM
The estimate for compound 3 lay 1.6-fold (0.21 log units) above the measured number; low and high end bracket the measured number.
By their numbers in this assay, from the lowest: compounds 3, 1 and 2 (each within the scatter of the next).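

In this assay, the place on a saturated chain carbon bound to an oxygen on an aromatic ring accepts 4-methoxyphenyl in place of 2-chlorophenyl (a 1.4-fold lower number from compound 2 to compound 3 (0.15 log units; within the scatter)) and an added methoxy group (a 1.3-fold lower number from compound 1 to compound 3 (0.13 log units; within the scatter)). Across compounds 1, 2 and 3, therefore, neither chloro nor methoxy moves the number beyond the scatter. No supporting data bear on why this is so. Still open, as far as these compounds go, is whether an amine, a carboxylic acid or a longer chain at this place would also stay within the scatter.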